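This account rests on a few compounds, and the source may have more. Where it says the series, first, only, none or still open, it means among the compounds named here.

Measured compounds:
Compound 1 `CCOC(=O)c1c(-c2cccc(C(F)(F)F)c2)[nH]c2cc(OC)ccc2c1=O`: > 21500 nM, a limit
Compound 2 `CCOC(=O)c1c(-c2cccc(S(C)(=O)=O)c2)[nH]c2cc(OC)ccc2c1=O`: > 21500 nM, a limit

In an ADME assay on Raji cells (Homo sapiens) for cytotoxicity, read by luminescence, with a stated time of 72 h (on this read-out lower numbers stand for an effect already at smaller amounts and higher numbers for an effect only at larger amounts of compound), compound 2 gives > 21500 nM, which is a limit and not a number. The two measured compounds share one reading: the limit of > 21500 nM in this assay, at which 2 of the 2 values shown sit. The next compound, compound 3 `CCOC(=O)c1c(-c2cccc(N(C)C)c2)[nH]c2cc(OC)ccc2c1=O`, carries dimethylamino in place of methylsulfonyl on an aromatic carbon, meta to a large group: dimethylamino in place of methylsulfonyl on an aromatic carbon.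

Among the compounds with values here, only one measured step bears on this change: a step that the two limits leave unreadable from compound 1 to compound 2. It also exchanges one group on an aromatic carbon, here methylsulfonyl in place of trifluoromethyl, but it yields no size to carry over. Within the data shown here, with that step as the only guide, no step beyond the scatter is expected in this assay, and no direction can be favoured. Compound 3 is therefore expected to be reported most likely as a limit again. For compound 3 the estimated value is 25000 nM, with an expected range from 10000 nM to 60000 nM. The expected step is a step that the limit leaves unreadable from compound 2 to compound 3.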

Compound 3, half-maximal effective concentration: > 21500 nM
Compound 3 gave a limit, no number (the forecaster's own chance of this, stated with the estimate: 75%); the middle value lies beyond the limit too.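

Compound 3 gives > 21500 nM, which is a limit and not a number, so no new step can be read among compound 1, compound 2 and compound 3: the limit of > 21500 nM in this assay, at which 3 of the 3 values shown sit.

The compounds shown leave open whether these three differ from one another at all, and whether any group on this aromatic carbon would give a measurable value.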